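The compounds below may be only part of what the source reports. "The series", "measured", "known", "first", "only" and "open" are said of these compounds alone.

This series rests on one shared core, carried by compound 1 `CC(C)(C)Nc1nc(N)c(C(=O)N=C(N)N)nc1Cl`, compound 2 `NC(N)=NC(=O)c1nc(Cl)c(NC2CC2)nc1N` and compound 3 `NC(N)=NC(=O)c1nc(Cl)c(NC2CCCCC2)nc1N`. Among the measured compounds shown here, in an assay for inhibition of acid-sensing ion channel 3 (Homo sapiens), read by patch clamp, tested at 1 uM (on this read-out lower numbers stand for less inhibition and higher numbers for more inhibition at the one concentration tested (going by the name of the read-out)), compound 3 gives 21%, and this is the only number in hand: in this assay compound 1 gives "not determined" (no result reported), and in this assay compound 2 gives "not determined" (no result reported). Compound 4 `NC(N)=NC(=O)c1nc(Cl)c(NCC2CCCCC2)nc1N` is the next member and differs from compound 3 in a single place: cyclohexylmethyl in place of cyclohexyl on a nitrogen on an aromatic ring. For the measured compounds named here, since no step between two measured compounds is available, the effect of putting cyclohexylmethyl in place of cyclohexyl can only be an expectation. The step is expected to be small, of a size within the usual scatter, in either direction: a number 4 percentage points higher from compound 3 to compound 4 (within the scatter). In this assay compound 4 is therefore estimated at 25%, with a range from 5% to 50%.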

Compound 4, a percentage reported as inhibition, at one concentration (the size of the read-out at that concentration, not a potency): 28%
Compound 4: the middle estimate sits 3 percentage points below what was measured, and the stated range covers the measured number.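

Putting cyclohexylmethyl in place of cyclohexyl on a nitrogen on an aromatic ring gives, in this assay, a number 7 percentage points higher from compound 3 to compound 4 (within the scatter). Among the compounds shown here, this is the first step that can be read at this position, and it shows that this change leaves the inhibition indistinguishable from that of the cyclohexyl compound. Nothing at hand bears on why the step has this size. Still open, from the compounds shown here alone, is whether a longer chain, or an amine or a carboxylic acid on the six-membered ring, would carry the inhibition beyond the scatter.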